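This account rests on a few compounds, and the source may have more. Where it says the series, first, only, none or still open, it means among the compounds named here.

Compound 1 `Cc1ccc(COc2ccc(-c3cc(CN4CCN(Cc5ccc(C(F)(F)F)cc5)CC4)no3)cc2)cc1` and compound 2 `Fc1ccc(COc2ccc(-c3cc(CN4CCN(Cc5ccc(C(F)(F)F)cc5)CC4)no3)cc2)cc1` share a core and differ in one place; the change is fluoro in place of methyl on an aromatic carbon. In a functional assay on MCF7 cells (Homo sapiens) for antiproliferative activity, read by sulforhodamine B assay, with a stated time of 72 h (on this read-out lower numbers stand for stronger inhibition and higher numbers for weaker inhibition), compound 1 gives 1200 nM, and compound 2 gives 7900 nM, so the step is a 6.6-fold higher number from compound 1 to compound 2 (0.82 log units; beyond the scatter). Compound 3 `Cc1cc(OCc2cccc(C#N)c2)ccc1-c1cc(CN2CCN(Cc3ccc(C(F)(F)F)cc3)CC2)no1` gives 400 nM in this assay, the lowest of the three numbers; the difference between its core and the core of compound 1 is not broken down here. Compound 4 `N#Cc1cccc(COc2ccc(-c3cc(CN4CCN(Cc5ccc(C(F)(F)F)cc5)CC4)no3)c(F)c2)c1` has not yet been measured. It differs from compound 3 by fluoro in place of methyl on an aromatic carbon, the same kind of change as that from compound 1 to compound 2, but not the same: there the fluoro stood para to a large group, here it stands ortho to a large group and meta to a (3-cyanobenzyl)oxy group. Among the measured compounds shown here, since the only measured example of this kind of change, from compound 1 to compound 2, raised the number, the step from compound 3 to compound 4 is expected to be a 3.0-fold higher number from compound 3 to compound 4 (0.48 log units; beyond the scatter), though the different surroundings make this uncertain. Compound 4 is therefore estimated at 1200 nM, with a range from 400 nM to 4000 nM.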

Compound 4, half-maximal inhibitory concentration: 1200 nM
For compound 4 middle estimate and measured number coincide at the digits printed, within the range that was stated.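

In this assay, fluoro in place of methyl on an aromatic carbon gives a 3.0-fold higher number from compound 3 to compound 4 (0.48 log units; beyond the scatter), so the number goes up on this core, as it did on the core of compound 1. Set side by side, the two steps do not differ by more than two such steps would be expected to scatter: the same change on two cores in this assay, a 6.6-fold higher number (0.82 log units; beyond the scatter) from compound 1 to compound 2 and a 3.0-fold higher number (0.48 log units; beyond the scatter) from compound 3 to compound 4, 2.2-fold (0.34 log units) apart, within the scatter of two such steps. This shows that, across these two pairs, the change carried over in direction and, as far as two pairs can tell, in size, even with the fluoro in different surroundings; it does not show that the change would carry over to other cores or other places on the ring, nor does it explain why the number goes up.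

The compounds shown leave open whether chloro, methoxy or a plain hydrogen in place of the methyl would follow the same course on either core. They also leave open what an amine or a carboxylic acid in place of the nitrile of compound 3 would do.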